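Cyclobutyl amide replacing the aryl amide in compound 2

The source may report more compounds than this note shows. Statements on the series, on what has been measured and on what is new or still open speak of the compounds shown alone.

Measured so far in an in vitro functional assay on CHO/Galpha16 cells for antagonist activity at C-C chemokine receptor type 8 (Homo sapiens), read by FLIPR; a lower number here means a stronger inhibitor, a higher number a weaker inhibitor:
compound 1, `CCCC(=O)N1CCC(NS(=O)(=O)c2ccc(NC(=O)c3ccc(C)cc3)c3ccccc23)CC1`, gives 9.5 nM
compound 2, `CCCCc1ccc(C(=O)Nc2ccc(S(=O)(=O)NC3CCN(C(=O)CCC)CC3)c3ccccc23)cc1`, gives 15.3 nM

Within the data shown here, compound 2 holds the higher of the two numbers in this assay, with compound 1 as its only neighbour; the single step between them, a 1.6-fold higher number from compound 1 to compound 2 (0.21 log units; within the scatter), is within the scatter, so the two values are not told apart.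

Compound 3, `CCCC(=O)N1CCC(NS(=O)(=O)c2ccc(NC(=O)C3CCC3)c3ccccc23)CC1`, is not yet measured. It differs from compound 2 by cyclobutyl in place of 4-butylphenyl on a carbonyl carbon.

The one measured step concerns the butyl on the aromatic ring and does not touch the ring itself; no step shown here exchanges an aromatic ring for a saturated one on that carbonyl carbon. The change in compound 3 is therefore unsupported by any measured step, and the estimate must be wide. Compound 3 is expected to give about 60 nM in this assay, with a range from 15 nM to 250 nM. The expected step is a 3.9-fold higher number from compound 2 to compound 3 (0.59 log units; beyond the scatter), a weakening beyond the scatter, held with low confidence.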

Compound 3, half-maximal inhibitory concentration: 57.9 nM
Beside the measured number, compound 3's estimate is 1.0-fold (0.02 log units) above it, and the stated range covers the measured number.
By their numbers in this assay, from the lowest: compounds 1 and 2 (each within the scatter of the next); then compound 3.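

In this assay, among these compounds, cyclobutyl on the carbonyl carbon gives the first step at this position that lies beyond the scatter: a 3.8-fold higher number from compound 2 to compound 3 (0.58 log units; beyond the scatter), and likewise a 6.1-fold higher number from compound 1 to compound 3 (0.78 log units; beyond the scatter). Both steps run in the same direction, so among these compounds the 4-butylphenyl and 4-methylphenyl groups, whose two compounds are not told apart, each give a lower number than cyclobutyl, yet an aromatic ring on the carbonyl carbon is not required for a measurable inhibitory value, with compound 3 at 57.9 nM. No evidence on the reason for this difference is available.

The change replaces a six-membered aromatic ring with a four-membered non-aromatic ring and also removes the chain on that ring, so the part played by each remains unresolved; unsubstituted phenyl and cyclohexyl on the same carbonyl carbon would be the informative comparisons. Also open, going by these compounds, is how an amine or a carboxylic acid in place of the butyl on the 4-butylphenyl group would read in this assay.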